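The source may report more compounds than this note shows. Statements on the series, on what has been measured and on what is new or still open speak of the compounds shown alone.

The series shares one core, seen in compound 1 `COc1ccc(Nc2cc(C)nc(SCc3nc4ccccc4[nH]3)n2)cc1`. In a functional assay on MGC-803 cells (Homo sapiens) for cytotoxicity, read by MTT assay, with a stated time of 72 h (a lower number here means a stronger inhibitor, a higher number a weaker inhibitor), compound 1 gives 51100 nM. Compound 2 `Cc1cc(NCCO)nc(SCc2nc3ccccc3[nH]2)n1` has 2-hydroxyethyl where compound 1 has 4-methoxyphenyl. In this assay compound 2 returns only a limit, > 100000 nM, so a number for it is not known. Compound 3 `Cc1cc(N2CCNCC2)nc(SCc2nc3ccccc3[nH]2)n1`, the piperazin-1-yl analogue, likewise returns only a limit, > 100000 nM. Going by these compounds, the step of an at least 1.9-fold higher number from compound 1 to compound 2 (0.29 log units; that floor lies within the scatter) and the step of an at least 1.9-fold higher number from compound 1 to compound 3 (0.29 log units; that floor lies within the scatter) both run into the limit (the limit of > 100000 nM in this assay, at which 2 of the 3 values shown sit), so their true size stays open. Compound 4 `Cc1cc(Nc2ccc(Br)cc2)nc(SCc2nc3ccccc3[nH]2)n1` differs from compound 2 in one place: 4-bromophenyl in place of 2-hydroxyethyl on a nitrogen on an aromatic ring. Among the measured compounds shown here, the one step that bears on this is an at least 1.9-fold higher number from compound 1 to compound 2 (0.29 log units; that floor lies within the scatter), which is the same kind of change run backwards, a chain on the ring nitrogen replacing an aromatic group, and it went toward weaker. Turning it round, the step of an at least 2.2-fold lower number from compound 2 to compound 4 (0.34 log units; beyond the scatter) is expected to bring the number back down to where an aromatic group on that nitrogen sits. Compound 4 is therefore estimated at 45000 nM, within 15000 nM to 130000 nM.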

Compound 4, half-maximal inhibitory concentration: 26800 nM
Beside the measured number, compound 4's estimate is 1.7-fold (0.23 log units) above it; low and high end bracket the measured number.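

In this assay, 4-bromophenyl in place of 2-hydroxyethyl on the nitrogen gives an at least 3.7-fold lower number from compound 2 to compound 4 (0.57 log units; beyond the scatter), and (4-bromophenyl)amino in place of piperazin-1-yl gives an at least 3.7-fold lower number from compound 3 to compound 4 (0.57 log units; beyond the scatter), so a group with an aromatic ring at this position now separates from these two groups by more than the scatter. The choice of substituent on that aromatic ring does not separate the two aryl analogues, as bromo in place of methoxy gives a 1.9-fold lower number from compound 1 to compound 4 (0.28 log units; within the scatter). The first two steps are floors and not sizes because compound 2 and compound 3 each return only a limit: the limit of > 100000 nM in this assay, at which 2 of the 4 values shown sit.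

Going by these compounds, it remains open how a chloro, nitrile or carboxylic acid group on the aromatic ring would compare with bromo and methoxy. A plain longer alkyl chain on the nitrogen would be needed to show whether the aromatic ring itself matters, rather than the loss of the hydroxyl.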